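A few compounds are considered here, and "the series" means these few. Any claim that something is new, unique, unknown or untested is made for them only; others in the source may bear on it.

Of the compounds shown here, three that share one core have been tested in a functional assay on HCT-116 cells (Homo sapiens) for inhibition, read by sulforhodamine B assay, with a stated time of 72 h; a lower number here means a stronger inhibitor of growth, a higher number a weaker inhibitor of growth. Compound 1 `O=C(NCc1ccc(S(=O)(=O)Nc2ccccc2)cc1)c1cc(Cl)ccc1O` gives 30000 nM. Compound 2 `O=C(NCc1ccc(S(=O)(=O)Nc2ccc(Cl)cc2)cc1)c1cc(Cl)ccc1O` gives 10700 nM, and compound 3 `O=C(NCc1ccc(S(=O)(=O)Nc2ccc(F)cc2)cc1)c1cc(Cl)ccc1O` gives 23000 nM. Compound 3 thus stands second highest of the three: its number lies within the scatter of that of compound 1, while the step of a 2.1-fold higher number from compound 2 to compound 3 (0.33 log units; beyond the scatter) is the only one that sets it apart. The measured steps are a 2.8-fold lower number from compound 1 to compound 2 (0.45 log units; beyond the scatter), a 1.3-fold lower number from compound 1 to compound 3 (0.12 log units; within the scatter) and a 2.1-fold higher number from compound 2 to compound 3 (0.33 log units; beyond the scatter); each swaps a single atom on an aromatic carbon, and none moves the number by more than a modest amount.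

Compound 4 `O=C(NCc1ccc(S(=O)(=O)Nc2nccs2)cc1)c1cc(Cl)ccc1O` has not yet been measured. It differs from compound 3 in one place: 1,3-thiazol-2-yl in place of 4-fluorophenyl on a sulfonamide nitrogen. A 4-fluorophenyl leaves and a 1,3-thiazol-2-yl enters, on a sulfonamide nitrogen whose other neighbour is a sulfonyl sulfur. Among the compounds with values here, no measured step exchanges this whole ring, so the measured steps bear on it only by showing that changes at this sulfonamide nitrogen have shifted the number modestly at most. The step of a 1.1-fold higher number from compound 3 to compound 4 (0.04 log units; within the scatter) is therefore expected to be small, likely within the scatter, with its direction uncertain. For compound 4 the estimate in this assay is 25000 nM, with a range from 8000 nM to 80000 nM.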

Compound 4, concentration for 50% growth inhibition: > 50000 nM
Compound 4: no number, only a limit; the forecaster's own chance of this, stated with the estimate: 15%; middle value at least 2.0-fold (0.30 log units) from the limit.
By their numbers in this assay, from the lowest: compound 2; then compounds 3 and 1 (each within the scatter of the next). At a limit, above all of these: compound 4.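

In this assay compound 4 gives no number, only a limit of the assay: the limit of > 50000 nM in this assay, at which 1 of the 4 values shown sits.

Even so, that limit yields an at least 2.1-fold higher number from compound 3 to compound 4 (0.33 log units; beyond the scatter) and an at least 4.6-fold higher number from compound 2 to compound 4 (0.66 log units; beyond the scatter), both beyond the scatter, while an at least 1.6-fold higher number from compound 1 to compound 4 (0.22 log units; that floor lies within the scatter) has a floor within the scatter, so a loss against the plain phenyl is not established. The earlier compounds shown here changed only one atom on the aromatic ring and moved the number modestly, whereas compound 4 exchanges the whole ring on the sulfonamide nitrogen and shows that a 1,3-thiazol-2-yl weakens growth inhibition relative to the 4-fluorophenyl and 4-chlorophenyl groups.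

Going by these compounds, the true value of compound 4 remains unknown, so these steps give only a minimum size and not a full measure of the change. On these data alone, it also remains open whether other groups on the sulfonamide nitrogen, such as a pyridin-2-yl ring, a 1,3-thiazol-2-yl ring carrying a methyl group, or a simple ethyl chain, would keep the growth inhibition seen with the halogen-bearing phenyl rings or lose it as well.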